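Methoxy to amino on the biphenyl phenol series

The source may hold more compounds than are shown below. What is called first, only, known or untested is meant among the compounds shown, and "the series" means these compounds.

Compound 1 `COc1ccccc1-c1cccc(O)c1` gives 44 ug/mL in a functional assay on MCF7 cells (Homo sapiens) for cytotoxicity, read by MTT assay, with a stated time of 3 days; a lower number here means a stronger inhibitor, a higher number a weaker inhibitor. Compound 2 `Nc1ccccc1-c1cccc(O)c1` gives 16 ug/mL in this assay. The change between them is amino in place of methoxy on an aromatic carbon, and it gave a 2.8-fold lower number from compound 1 to compound 2 (0.44 log units; beyond the scatter). Compound 3 `COc1ccc(-c2cccc(O)c2)cc1` gives 48 ug/mL in this assay; the difference between the cores of compound 1 and compound 3 is not broken down here, and their two values lie within the scatter of each other. Compound 4 `Nc1ccc(-c2cccc(O)c2)cc1` differs from compound 3 by amino in place of methoxy on an aromatic carbon. This is the same kind of change as that from compound 1 to compound 2, but the place differs: in compound 2 the amino is ortho to a group of 7 heavy atoms, in compound 4 it is para to a group of 7 heavy atoms. A step of similar size is expected, a 2.7-fold lower number from compound 3 to compound 4 (0.43 log units; beyond the scatter), resting on compound 1 giving 44 ug/mL and compound 2 giving 16 ug/mL. Compound 4 is therefore estimated at 18 ug/mL in this assay.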

Compound 4, half-maximal inhibitory concentration: > 100 ug/mL
Compound 4: no number, only a limit; the forecaster's own chance of this, stated with the estimate: 5%; middle value at least 5.5-fold (0.74 log units) away from the limit.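

In this assay, amino in place of methoxy on an aromatic carbon gave an at least 2.0-fold higher number from compound 3 to compound 4 (0.31 log units; beyond the scatter), so the step seen on the core of compound 1 did not carry over to the core of compound 3, and its direction reversed: the same change on two cores in this assay, a 2.8-fold lower number (0.44 log units; beyond the scatter) from compound 1 to compound 2 and an at least 2.0-fold higher number (0.31 log units; beyond the scatter) from compound 3 to compound 4, at least 5.7-fold (0.75 log units) apart, beyond the scatter of two such steps. The entry for compound 4, > 100 ug/mL, is a limit of the assay and not a number: the limit of > 100 ug/mL in this assay, at which 1 of the 4 values shown sits. This rests on one pair per core; it shows that the change cannot be transferred between these two cores, but not why, nor how large the step from compound 3 truly is.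

Going by these compounds, whether other groups would split the same way stays open. A dimethylamino group or an acetamide on the same two cores would test this.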